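This account rests on a few compounds, and the source may have more. Where it says the series, first, only, none or still open, it means among the compounds named here.

In a functional assay on cells (leukaemia cell line, Homo sapiens) for inhibition, read by sulforhodamine B assay, with a stated time of 48 h (on this read-out lower numbers stand for higher toxicity in this test and higher numbers for lower toxicity in this test), the measured compounds share one core and differ in the phenyl group on the sulfonamide nitrogen. Compound 1 `O=S(=O)(Nc1ccc(Br)c(Cl)c1)c1ccc(-c2cnc(C3CC3)o2)cc1` gives > 100000 nM, which is a limit of the assay and not a number. Compound 2 `Cc1ccc(NS(=O)(=O)c2ccc(-c3cnc(C4CC4)o3)cc2)cc1C`, with its 3,4-dimethylphenyl group, gives > 100000 nM, also a limit. Compound 3 `O=S(=O)(Nc1cc(F)cc(Cl)c1)c1ccc(-c2cnc(C3CC3)o2)cc1` gives > 100000 nM, again a limit. Compound 3 therefore stands with the others at the limit of > 100000 nM in this assay, at which 3 of the 3 values shown sit.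

Compound 4 `Cc1cc(Cl)cc(NS(=O)(=O)c2ccc(-c3cnc(C4CC4)o3)cc2)c1` carries methyl in place of fluoro on an aromatic carbon, meta to a chloro group, turning 3-chloro-5-fluorophenyl into 3-chloro-5-methylphenyl: methyl in place of fluoro on an aromatic carbon. The measured steps that bear on this change are a step that the two limits leave unreadable from compound 1 to compound 3 and a step that the two limits leave unreadable from compound 2 to compound 3. Neither has a size that can be read, so they offer no sign of a change. No shift beyond the scatter is therefore expected in this assay, in either direction. The expected change is a number no higher from compound 3 to compound 4 (the limit leaves the size open). For compound 4 the estimate is 100000 nM, with an expected range from 40000 nM to 200000 nM.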

Compound 4, concentration lethal to 50% of the cells: 84900 nM
Compound 4: middle estimate off by 1.2-fold (0.07 log units), on the high side, within the range that was stated.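

In this assay compound 4 is the only compound shown with a measured number instead of a limit, which gives this set its first readable point, while the others stay at one ceiling: the limit of > 100000 nM in this assay, at which 3 of the 4 values shown sit.

Methyl in place of fluoro on this aromatic carbon gives an at least 1.1-fold lower number from compound 3 to compound 4 (0.07 log units; that floor lies within the scatter), and the wider changes of the phenyl group give an at least 1.1-fold lower number from compound 2 to compound 4 (0.07 log units; that floor lies within the scatter) and an at least 1.1-fold lower number from compound 1 to compound 4 (0.07 log units; that floor lies within the scatter). Each of these is only a floor that lies within the scatter, so it cannot be said that the change moved the result.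

The steps among compound 1, compound 2 and compound 3 cannot be read, since all three values are limits. From the compounds shown here alone, whether an amine, a carboxylic acid or a longer chain on this aromatic carbon would give a number clearly beyond the scatter stays open.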